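Swapping a phenyl for trifluoromethoxy on an indole ketone

A few compounds are considered here, and "the series" means these few. Any claim that something is new, unique, unknown or untested is made for them only; others in the source may bear on it.

Of the compounds shown here, three of one series have been measured in an assay on isolated protein for inhibition of Indoleamine 2,3-dioxygenase 1 (Homo sapiens), read by spectrophotometry; on this read-out lower numbers stand for stronger inhibition and higher numbers for weaker inhibition. Compound 1 `O=C(Cc1cccnc1)c1cc2cc(-c3ccccc3)ccc2[nH]1` gives 96000 nM in this assay. Compound 2 `O=C(Cc1cnccn1)c1cc2ccccc2[nH]1` gives 26200 nM, and compound 3 `Cn1c(C(=O)Cc2cccnc2)cc2ccccc21` gives 34000 nM. Compound 1 therefore stands at the highest number of the three, which makes it the weakest inhibitor of the set: compound 3 lies nearest to it but still beyond the scatter, and compound 2 lies furthest away, also beyond the scatter.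

Compound 4 `O=C(Cc1cccnc1)c1cc2cc(OC(F)(F)F)ccc2[nH]1` is not yet measured. It differs from compound 1 in one place: trifluoromethoxy in place of phenyl on an aromatic carbon. Going by the values given here, no pair of measured compounds shows this kind of exchange, so the size of the step has to be guessed from what the series shows. Compound 2 and compound 3 carry no group at that position and give lower numbers than compound 1, which suggests that the phenyl is not what holds compound 1 in the set, and that losing it need not cost anything. The step is expected to be small, toward a lower number or none beyond the scatter, as a 2.4-fold lower number from compound 1 to compound 4 (0.38 log units; beyond the scatter) describes. Compound 4 is therefore estimated at 40000 nM in this assay, with a range from 12000 nM to 130000 nM.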

Compound 4, half-maximal inhibitory concentration: 13100 nM
Compound 4: the middle estimate sits 3.1-fold (0.48 log units) above what was measured; the range from low to high includes it.
By their numbers in this assay, from the lowest: compounds 4, 2 and 3 (each within the scatter of the next, the first and the last beyond it); then compound 1.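

In this assay, going by these compounds alone, trifluoromethoxy in place of phenyl gives a 7.3-fold lower number from compound 1 to compound 4 (0.86 log units; beyond the scatter), the only step that can be read at this aromatic carbon. It shows that this position is sensitive to what it carries, and that the phenyl can be given up for a group with no ring and still leave a lower number, with the step lying beyond the scatter. The data do not tell which part of the exchange, the loss of the six-membered aromatic ring or the arrival of the oxygen and fluorine atoms, accounts for the step.

Within the data shown here, the single pair cannot separate those two parts, so it remains open whether methoxy, chlorine or an amine on the same aromatic carbon would give a number like that of compound 4 or a clearly different one. From the compounds shown here alone, it also remains open whether trifluoromethoxy at this position would produce a step of similar size on the core of compound 2 or compound 3, which differ from compound 4 in more than one place.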